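This account rests on a few compounds, and the source may have more. Where it says the series, first, only, none or still open, it means among the compounds named here.

Of the compounds shown here, three sharing one core have been tested in a functional assay on NCI-H460 cells (Homo sapiens) for antiproliferative activity, read by sulforhodamine B assay, with a stated time of 48 h; a lower number here means a stronger inhibitor, a higher number a weaker inhibitor. Compound 1 `CO/N=C1/C(=O)N(CCCCCCC(=O)NO)c2ccccc21`, with hydrogen on the aromatic carbon that varies, gives 750 nM. Compound 2 `CO/N=C1/C(=O)N(CCCCCCC(=O)NO)c2ccc(Cl)cc21`, with chloro on that carbon, gives 760 nM, and compound 3 `CO/N=C1/C(=O)N(CCCCCCC(=O)NO)c2ccc(Br)cc21`, with bromo there, gives 2900 nM. Compound 3 therefore has the highest number of the three and is the weakest inhibitor of the set.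

The next compound, compound 4 `CO/N=C1/C(=O)N(CCCCCCC(=O)NO)c2ccc(C)cc21`, has methyl in place of bromo on an aromatic carbon. Among the measured compounds shown here, no measured step involves methyl, so the evidence is indirect. Chloro in place of hydrogen gives a 1.0-fold higher number from compound 1 to compound 2 (0.01 log units; within the scatter), so that change leaves the number where it was. Bromo in place of hydrogen gives a 3.9-fold higher number from compound 1 to compound 3 (0.59 log units; beyond the scatter), and bromo in place of chloro gives a 3.8-fold higher number from compound 2 to compound 3 (0.58 log units; beyond the scatter), both modest. Only the bromo compound stands apart so far, and compound 4 no longer carries bromo. The expectation in this assay is therefore a modest drop towards the values of the other two compounds, though methyl could behave differently from both hydrogen and chloro. The expected change is a 2.9-fold lower number from compound 3 to compound 4 (0.46 log units; beyond the scatter). For compound 4 the estimated value is 1000 nM, with an expected range of 400 nM to 2800 nM.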

Compound 4, half-maximal inhibitory concentration: 1190 nM
Compound 4: middle estimate off by 1.2-fold (0.08 log units), on the low side; the measured number falls inside the stated range.
By their numbers in this assay, from the lowest: compounds 1, 2 and 4 (each within the scatter of the next); then compound 3.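

Methyl in place of bromo on this aromatic carbon in this assay gives a 2.4-fold lower number from compound 3 to compound 4 (0.39 log units; beyond the scatter) and so moves the number back by a modest step. Methyl in place of chloro gives a 1.6-fold higher number from compound 2 to compound 4 (0.19 log units; within the scatter) and methyl in place of hydrogen gives a 1.6-fold higher number from compound 1 to compound 4 (0.20 log units; within the scatter); both steps lie within the scatter, so hydrogen, chloro and methyl cannot be told apart at this position, and among these four compounds only bromo stands apart. Bromo and methyl each count a single heavy atom, so that count does not separate them, and nothing measured here explains why bromo alone shifts the number.

The compounds shown leave open whether the position would accept larger or differently built groups, such as ethyl, methoxy, an amine or a carboxylic acid, as it accepts hydrogen, chloro and methyl, or whether they would shift the number as bromo does. They also leave open whether any group on this carbon can bring the number clearly below that of compound 1, since none of the three substituents shown does so.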